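The compounds below may be only part of what the source reports. "The series", "measured", "known", "first", "only" and "open" are said of these compounds alone.

In an ADME assay on microsomes from liver (Homo sapiens) for metabolic stability (a higher number here means faster removal of the compound, a lower number slower removal), compound 1 `CNC(=O)CN1CCC(c2cc3c(-c4ccc(=O)n(C(C)C)c4)ccnc3[nH]2)CC1` gives 8.6 uL/min. Two related compounds sit higher on the same scale: compound 2 `CC(C)n1cc(-c2ccnc3[nH]c(C4CCN(CC(=O)N(C)C)CC4)cc23)cnc1=O` gives 24 uL/min, and compound 3 `CC(C)Cn1cc(-c2ccnc3[nH]c(C4CCN(CC(=O)N(C)C)CC4)cc23)ccc1=O` gives 21 uL/min. Compound 1 therefore has the lowest number of the three, with compound 3 the nearer of the two others and compound 2 the further, and both of these gaps fall beyond the usual scatter of repeated measurements. No pair among these three measured compounds differs in only one place, so no single-point step can be read from them.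

Compound 4 `CC(C)n1cc(-c2ccnc3[nH]c(C4CCN(Cc5cccs5)CC4)cc23)ccc1=O` has not yet been measured in this assay. It differs from compound 1 in one place: thiophen-2-yl in place of methylcarbamoyl on a saturated chain carbon bound to an amine nitrogen in a ring. Among the measured compounds shown here, with no measured pair tracing a similar exchange, nothing here fixes the size of that step directly. The step is nonetheless expected to go upward, beyond the scatter: a 3.5-fold higher number from compound 1 to compound 4 (0.54 log units; beyond the scatter). Compound 4 is accordingly estimated at 30 uL/min, with a likely range from 12 uL/min to 75 uL/min.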

Compound 4, intrinsic clearance in a liver preparation (reported as CLH), per the amount of preparation that the assay uses: 84 uL/min
Compound 4: middle estimate off by 2.8-fold (0.45 log units), on the low side; the measured number lies above the stated range.
By their numbers in this assay, from the lowest: compound 1; then compounds 3 and 2 (each within the scatter of the next); then compound 4.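

In this assay, the group on a saturated chain carbon bound to an amine nitrogen in a ring proves to have a large bearing on the number: thiophen-2-yl in place of methylcarbamoyl gives a 9.8-fold higher number from compound 1 to compound 4 (0.99 log units; beyond the scatter), a step beyond the scatter. This is the only single-place step shown, and it establishes that the read-out at this position can change substantially with the group it carries. No measurement shown here explains why the number moves so far.

This one exchange cannot separate the effect of gaining thiophen-2-yl from that of losing methylcarbamoyl. From the compounds shown here alone, how this assay would respond to a phenyl ring or a carboxylic acid at the same place remains open, as does whether the step would hold on a different core.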